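Ester to Acid on the Benzyl Arm: Cytotoxicity Outlook

A few compounds are considered here, and "the series" means these few. Any claim that something is new, unique, unknown or untested is made for them only; others in the source may bear on it.

Measured compounds:
compound 1 `COc1ccc(CN2C(=O)/C(=C/c3cc(C)n(-c4ccc(O)c(C(=O)O)c4)c3C)SC2=S)cc1` gives 75300 nM
compound 2 `Cc1cc(/C=C2\SC(=S)N(Cc3cccc(C(F)(F)F)c3)C2=O)c(C)n1-c1ccc(O)c(C(=O)O)c1` gives 26300 nM
compound 3 `COC(=O)c1cccc(CN2C(=O)/C(=C/c3cc(C)n(-c4ccc(O)c(C(=O)O)c4)c3C)SC2=S)c1` gives 38500 nM

In an ADME assay on MT2 cells (Homo sapiens) for cytotoxicity, read by XTT assay, with a stated time of 4 days (a lower number here means that less compound is tolerated, a higher number that more compound is tolerated), compound 3 stands second highest of the three numbers. Its nearest neighbour is compound 2, with a 1.5-fold higher number from compound 2 to compound 3 (0.17 log units; within the scatter), and its furthest is compound 1, with a 2.0-fold lower number from compound 1 to compound 3 (0.29 log units; within the scatter); both gaps lie within the scatter. For the measured compounds named here, the only step beyond the scatter is a 2.9-fold lower number from compound 1 to compound 2 (0.46 log units; beyond the scatter).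

Compound 4 `Cc1cc(/C=C2\SC(=S)N(Cc3cccc(C(=O)O)c3)C2=O)c(C)n1-c1ccc(O)c(C(=O)O)c1` differs from compound 3 in one place: hydrogen in place of methyl on an oxygen next to a carbonyl group. Going by the values given here, no measured step removes a methyl from an oxygen next to a carbonyl group; the steps that bear on it are those that exchange the group on the benzyl-side phenyl, and two of the three of these stayed within the scatter. Compound 4 is therefore expected to give 40000 nM in this assay, with a range from 15000 nM to 110000 nM. The expected step is a 1.0-fold higher number from compound 3 to compound 4 (0.02 log units; within the scatter), none beyond the scatter.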

Compound 4, half-maximal cytotoxic concentration: > 100000 nM
Compound 4 gave a limit, no number (the forecaster's own chance of this, stated with the estimate: 15%); at least 2.5-fold (0.39 log units) between middle value and limit.
By their numbers in this assay, from the lowest: compounds 2, 3 and 1 (each within the scatter of the next, the first and the last beyond it). At a limit, above all of these: compound 4.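

In this assay compound 4 reads as a limit and not a number: the limit of > 100000 nM in this assay, at which 1 of the 4 values shown sits. Hydrogen in place of methyl on an oxygen next to a carbonyl group gives an at least 2.5-fold higher number from compound 3 to compound 4 (0.41 log units; beyond the scatter), so this change moves the read-out beyond the scatter, whereas methoxycarbonyl in place of trifluoromethyl did not. Carboxy in place of trifluoromethyl gives an at least 3.8-fold higher number from compound 2 to compound 4 (0.58 log units; beyond the scatter), while the comparison with the 4-methoxyphenyl arm gives only an at least 1.3-fold higher number from compound 1 to compound 4 (0.12 log units; that floor lies within the scatter), so 3-carboxyphenyl cannot be ranked against that arm.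

From the compounds shown here alone, how far the true value of compound 4 lies past its limit remains open. So does whether a primary amide or a hydroxymethyl group in the place of the carboxy would read like the carboxy or like the methoxycarbonyl.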